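Ester acyl and chain substituent changes in a growth-inhibition series

This account rests on a few compounds, and the source may have more. Where it says the series, first, only, none or still open, it means among the compounds named here.

Measured compounds:
compound 1 `CC(=O)OC/C(=C\C1CCCCC1)C(=O)c1ccccc1` — 19000 nM
compound 2 `O=C(OC/C(=C\C1CCCCC1)C(=O)c1ccccc1)c1ccccc1` — 17000 nM

Among the measured compounds shown here, in a functional assay on SW1573 cells (Homo sapiens) for inhibition, read by sulforhodamine B assay, with a stated time of 48 h (on this read-out higher numbers stand for weaker inhibition of growth and lower numbers for stronger inhibition of growth), compound 2 gives 17000 nM, the lowest of the two numbers so far, and its only neighbour is compound 1 at 19000 nM. For the measured compounds named here, the one measured step, a 1.1-fold lower number from compound 1 to compound 2 (0.05 log units; within the scatter), lies within the scatter, so the two compounds are not distinguished on this read-out.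

Compound 3 `O=C(OC/C(=C\c1ccccc1[N+](=O)[O-])C(=O)c1ccccc1)c1ccccc1` is not yet measured. It differs from compound 2 by 2-nitrophenyl in place of cyclohexyl on a double-bonded chain carbon bound to a double-bonded chain carbon. Going by the values given here, no measured step touches this position: the step from compound 1 to compound 2 concerns the ester acyl group, not the chain substituent, so it gives no guide to the direction or size of change in this assay here. With nothing to lean on, the number for compound 3 is estimated near that of compound 2, and the step of a 1.1-fold lower number from compound 2 to compound 3 (0.05 log units; within the scatter) is expected to stay within the scatter, with a wide range either way. Compound 3 is thus estimated at 15000 nM, between 3000 nM and 70000 nM.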

Compound 3, concentration for 50% growth inhibition: 4300 nM
Beside the measured number, compound 3's estimate is 3.5-fold (0.54 log units) above it; low and high end bracket the measured number.
By their numbers in this assay, from the lowest: compound 3; then compounds 2 and 1 (each within the scatter of the next).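

In this assay, the double-bonded chain carbon bound to a double-bonded chain carbon proves sensitive to substitution: 2-nitrophenyl in place of cyclohexyl gives a 4.0-fold lower number from compound 2 to compound 3 (0.60 log units; beyond the scatter), whereas the change of ester acyl group gave only a 1.1-fold lower number from compound 1 to compound 2 (0.05 log units; within the scatter). Among the compounds shown here, this is therefore the first single change to move the number beyond the scatter, though the step is modest in size. No supporting evidence bears on why the number falls at this position.

The compounds shown do not separate the aromatic ring from the nitro group, so an unsubstituted phenyl or an amine in place of the nitro group at this position would be informative. On these data alone, it also remains open whether the ester acyl group stays as silent with 2-nitrophenyl on the chain as it does with cyclohexyl.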